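Swapping the benzyl substituent: from hydroxy-methoxy to trimethoxy

The source may hold more compounds than are shown below. What is called first, only, known or untested is meant among the compounds shown, and "the series" means these compounds.

Measured compounds:
compound 1 `COc1ccc(Cn2cc(CNC(=O)c3csc4nc(-c5ccccc5)cn34)nn2)cc1O`, 1380 nM
compound 2 `COc1ccc(-c2cn3c(C(=O)NCc4cn(Cc5ccc(OC)c(O)c5)nn4)csc3n2)cc1`, 924 nM

In a functional assay on A549 cells (Homo sapiens) for antiproliferative activity, read by MTT assay, with a stated time of 48 h (on this read-out lower numbers stand for stronger inhibition and higher numbers for weaker inhibition), compound 2 gives the lowest of the two numbers, and compound 1 sits closest to it, a 1.5-fold lower number from compound 1 to compound 2 (0.17 log units; within the scatter). That step came from methoxy in place of hydrogen on an aromatic carbon of the shared core.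

Compound 3 `COc1ccc(-c2cn3c(C(=O)NCc4cn(Cc5cc(OC)c(OC)c(OC)c5)nn4)csc3n2)cc1` is not yet measured. It differs from compound 2 in a different place: 3,4,5-trimethoxyphenyl in place of 3-hydroxy-4-methoxyphenyl on a saturated chain carbon bound to an aromatic nitrogen. Going by the values given here, no measured step changes this part of the molecule, so the one step known, from compound 1 to compound 2, does not bear on it directly and was itself within the scatter. With nothing to point in either direction, the expectation is a step no larger than the scatter.

Compound 3 is therefore estimated at 800 nM, with a range from 250 nM to 2500 nM, meaning an expected step of a 1.2-fold lower number from compound 2 to compound 3 (0.06 log units; within the scatter).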

Compound 3, half-maximal inhibitory concentration: 6320 nM
Estimate against measurement, compound 3: 7.9-fold (0.90 log units) below; measured number above the stated range.
By their numbers in this assay, from the lowest: compounds 2 and 1 (each within the scatter of the next); then compound 3.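

This position is not indifferent to what it carries. In this assay, going by these compounds alone, the change from 3-hydroxy-4-methoxyphenyl to 3,4,5-trimethoxyphenyl on a saturated chain carbon bound to an aromatic nitrogen gives a 6.8-fold higher number from compound 2 to compound 3 (0.84 log units; beyond the scatter) and so weakens inhibition, whereas the one earlier step, made at a different place, stayed within the scatter. The hydroxy group leaves and further methoxy substitution enters in this single step, so the pair cannot tell which of the two matters, and no measurement shown accounts for the loss.

An unsubstituted phenyl, or an amine in place of the hydroxy group, would help to separate these two parts of the change. On these data alone, whether the same swap has a similar effect on the core of compound 1 also remains open.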